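Notes on the step from compound 2 to compound 3

The compounds below may be only part of what the source reports. "The series", "measured", "known", "first", "only" and "open" are said of these compounds alone.

Measured in a functional assay on HepG2 cells (Homo sapiens) for inhibition, read by MTT assay, with a stated time of 48 h; on this read-out higher numbers stand for weaker inhibition and lower numbers for stronger inhibition:
- compound 1 `CCOC(=O)C1=C(N/N=C(/Cl)c2ccc([N+](=O)[O-])cc2)Nc2[nH]nc(C)c2C1c1ccc(N(C)C)cc1`: 55500 nM
- compound 2 `CCOC(=O)C1=C(N/N=C(/Cl)C#N)Nc2[nH]nc(C)c2C1c1ccc(N(C)C)cc1`: 23600 nM

Among the measured compounds shown here, compound 2 holds the lower of the two numbers so far, and compound 1 is its only neighbour. The next structure is compound 3 `CCOC(=O)C1=C(N/C=N/c2ccc([N+](=O)[O-])cc2)Nc2[nH]nc(C)c2C1c1ccc(N(C)C)cc1`, and the change leading to it is a group of 11 heavy atoms (7 carbon, 2 nitrogen, 2 oxygen; one six-membered aromatic ring of carbon only) in place of a group of 5 heavy atoms (2 carbon, 2 nitrogen, 1 chlorine; no ring), on an amine nitrogen. For the measured compounds named here, one measured step bears on this: a 2.4-fold lower number from compound 1 to compound 2 (0.37 log units; beyond the scatter), with cyano in place of 4-nitrophenyl on a carbon with a double bond to nitrogen. That step is modest. Compound 3 again carries 4-nitrophenyl, but its connection to the shared core differs from that in compound 1, so the step is only a loose guide. No measurement isolates that difference. A modest rise is expected in this assay, with the estimated step being a 1.8-fold higher number from compound 2 to compound 3 (0.25 log units; within the scatter). For compound 3 the expected value is 42000 nM, with an estimated range of 14000 nM to 110000 nM.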

Compound 3, half-maximal inhibitory concentration: 50900 nM
Beside the measured number, compound 3's estimate is 1.2-fold (0.08 log units) below it; the range from low to high includes it.
By their numbers in this assay, from the lowest: compound 2; then compounds 3 and 1 (each within the scatter of the next).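

In this assay, the group of 11 heavy atoms on the amine nitrogen gives a 2.2-fold higher number from compound 2 to compound 3 (0.33 log units; beyond the scatter), so a second aromatic-ring group at this position also stands above compound 2, whose nitrile-bearing group of 5 heavy atoms has no ring. The two ring-bearing groups cannot be separated, with a 1.1-fold lower number from compound 1 to compound 3 (0.04 log units; within the scatter), so the different connection to the shared core and the absence of chlorine in compound 3 give no readable difference in this assay. Nothing measured here accounts for these steps.

Open, on these data alone, is whether an amine or a carboxylic acid in place of the nitro group on the aromatic ring would move the number. Also open, as far as these compounds go, is whether a longer chain ending in a nitrile would hold the value of compound 2 or go beyond it.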